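Isopropylamino in place of carbamoylpiperidinyl on the shared core

The source may report more compounds than this note shows. Statements on the series, on what has been measured and on what is new or still open speak of the compounds shown alone.

Within the data shown here, compound 2 `COc1cc2nc(N3CCC(C(N)=O)CC3)nc(NC3CCCCCC3)c2cc1OC` gives 17% in an in vitro functional assay on B300-19 cells for antagonist activity at C-C chemokine receptor type 4 (Homo sapiens), read by GTPgammaS binding, tested at 1 uM (on this read-out higher numbers stand for more inhibition at the one concentration tested (going by the name of the read-out) and lower numbers for less inhibition), and stands highest of the two numbers so far; compound 1 `COc1cc2nc(NCc3cccs3)nc(NC3CCCCCC3)c2cc1OC` gives 0% in this assay. Among the measured compounds shown here, the one known step, a number 17 percentage points higher from compound 1 to compound 2 (beyond the scatter), concerns a different pair of groups and so only loosely informs the present change. Compound 3 `COc1cc2nc(NC(C)C)nc(NC3CCCCCC3)c2cc1OC` differs from compound 2 thus: isopropylamino in place of 4-carbamoylpiperidin-1-yl on an aromatic carbon. For the measured compounds named here, with no measured step directly bearing on this swap, the expected change is a number 9 percentage points lower from compound 2 to compound 3 (within the scatter), a step not beyond the scatter, if anything downward. Compound 3 is estimated to give 8% in this assay, with a range of -10% to 30%.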

Compound 3, a percentage reported as inhibition, at one concentration (the size of the read-out at that concentration, not a potency): < 0%
Compound 3: no number, only a limit; the forecaster's own chance of this, stated with the estimate: 0%; middle value at least 8 percentage points away from the limit.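

In this assay compound 3 gives < 0%, which is a limit of the assay and not a number. At this aromatic carbon between two ring nitrogen atoms, isopropylamino in place of 4-carbamoylpiperidin-1-yl gives a number at least 17 percentage points lower from compound 2 to compound 3 (beyond the scatter), a step of at least modest size, so the inhibition of compound 2 does not carry over to this open-chain amine. Isopropyl in place of (thiophen-2-yl)methyl on a nitrogen on an aromatic ring gives a number no higher from compound 1 to compound 3 (the limit leaves the size open), and the size of this step cannot be read.

From the compounds shown here alone, whether the inhibition of compound 2 goes with the piperidine ring or with its carbamoyl group stays open. An unsubstituted piperidin-1-yl or a 4-carboxypiperidin-1-yl at this place would separate the two.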